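Benzenesulfonamide series: chloro to methoxy on the aryl ring

The source may hold more compounds than are shown below. What is called first, only, known or untested is meant among the compounds shown, and "the series" means these compounds.

Measured so far, in a functional assay on MIA PaCa-2 cells (Homo sapiens) for inhibition, read by MTT assay, with a stated time of 72 h; a higher number here means a weaker inhibitor of growth, a lower number a stronger inhibitor of growth:
compound 1 `CCCCc1ccc(S(=O)(=O)NCCCCCCNCc2ccc(Br)cc2)cc1` gives 5700 nM
compound 2 `CC(C)(C)c1ccc(CNCCCNS(=O)(=O)c2cc(C(F)(F)F)cc(C(F)(F)F)c2)cc1` gives 2300 nM
compound 3 `O=S(=O)(NCCCCCCNCc1ccc(Br)cc1)c1ccc(Cl)cc1` gives 5900 nM

Compound 3 holds the highest of the three numbers in this assay. Its nearest neighbour is compound 1, which sits within the scatter of it; compound 2 is the furthest away, a gap beyond the scatter. Among the compounds with values here, the one single-point step so far, a 1.0-fold higher number from compound 1 to compound 3 (0.01 log units; within the scatter), shows that swapping butyl for chloro on the aromatic carbon left the number where it was.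

Compound 4 `COc1ccc(S(=O)(=O)NCCCCCCNCc2ccc(Br)cc2)cc1` is the next case. The change from compound 3 is methoxy in place of chloro on an aromatic carbon. Within the data shown here, no measured pair covers a chloro-to-methoxy exchange, so the only guide is that the same aromatic position tolerated the butyl-to-chloro exchange without a shift beyond the scatter. On that basis the step of a 1.0-fold higher number from compound 3 to compound 4 (0.01 log units; within the scatter) is expected to stay within the scatter, with no clear direction. Compound 4 is therefore estimated at 6000 nM in this assay, with a likely range of 3000 nM to 12000 nM.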

Compound 4, concentration for 50% growth inhibition: 13000 nM
Estimate against measurement, compound 4: 2.2-fold (0.34 log units) below; measured number above the stated range.
By their numbers in this assay, from the lowest: compound 2; then compounds 1 and 3 (each within the scatter of the next); then compound 4.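

In this assay, this aromatic carbon, para to a large group, is not indifferent to what it carries: butyl and chloro sit within the scatter of each other, whereas methoxy gives a 2.2-fold higher number from compound 3 to compound 4 (0.34 log units; beyond the scatter) and a 2.3-fold higher number from compound 1 to compound 4 (0.36 log units; beyond the scatter). Among the three groups compared here, methoxy alone moves the number beyond the scatter, and the move is towards weaker growth inhibition against both chloro and butyl, though both steps are modest. Methoxy brings one hydrogen-bond acceptor where chloro brings none, but no measurement on hand accounts for the shift.

Going by these compounds, whether an ethoxy, a hydroxyl or an amine at this carbon would follow methoxy remains open. Also open, on these data alone, is whether the same exchange would give a similar step on the core of compound 2.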